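Chloro to hydroxy among closely grouped compounds

The source may report more compounds than this note shows. Statements on the series, on what has been measured and on what is new or still open speak of the compounds shown alone.

Measured in a functional assay, read by Griess assay, with a stated time of 2.5 h (on this read-out higher numbers stand for weaker inhibition and lower numbers for stronger inhibition), compound 1 `COc1cc(OC)c(OC)cc1/C=C/C(=O)c1cc(Cc2ccccc2)cc(Cc2ccccc2)c1` gives 2.09 ug/mL, compound 2 `COc1cc(OC)c(-c2cc(=O)c3cc(Cl)ccc3o2)cc1OC` gives 2.15 ug/mL and compound 3 `COc1cc(OC)c(OC)cc1/C=C/C(=O)c1ccc(C)cc1` gives 2.18 ug/mL. Compound 2 stands together with the other two. All three numbers lie within the usual scatter of one another, so they set no order among these compounds.

Compound 4 `COc1cc(OC)c(-c2cc(=O)c3cc(O)ccc3o2)cc1OC` has not yet been measured. It keeps the core of compound 2 but carries hydroxy in place of chloro on an aromatic carbon, meta to a fused ring and para to a fused ring: hydroxy in place of chloro on an aromatic carbon. Going by the values given here, no two measured compounds differ in one place only, so the data give no direct measure of this exchange. Among the compounds with values here, the only guide is that compound 1 and compound 2 have clearly different structures and still show values within the scatter, as do compound 1 and compound 3. On that limited basis, no step beyond the scatter is expected in this assay, and no firm direction can be assigned. The estimated change is a 1.1-fold higher number from compound 2 to compound 4 (0.05 log units; within the scatter) and is expected to stay within the scatter. For compound 4 the estimated value is 2.4 ug/mL, with an expected range from 1.1 ug/mL to 5.2 ug/mL.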

Compound 4, half-maximal inhibitory concentration: 2.14 ug/mL
Estimate against measurement, compound 4: 1.1-fold (0.05 log units) above, within the range that was stated.
By their numbers in this assay, from the lowest: compounds 1, 4, 2 and 3 (each within the scatter of the next).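

Going by these compounds alone, this pair gives the first direct reading of a single exchange, which the earlier compounds, differing in more than one place, could not provide: in this assay hydroxy in place of chloro on an aromatic carbon, meta to a fused ring and para to a fused ring, amounts to a 1.0-fold lower number from compound 2 to compound 4 (0.00 log units; within the scatter). On the core of compound 2, then, a chlorine atom with no hydrogen-bond donor or acceptor can give way to a hydroxy group, with one of each, and the read-out stays within the scatter. Nothing at hand bears on why the two groups read alike.

What the compounds shown leave open is how far this tolerance extends, since chloro and hydroxy are the only groups seen at this place, and an amine, a carboxylic acid or a longer chain there could read alike or quite differently. On these data alone, it also remains open whether the same exchange would stay within the scatter on another core, such as that of compound 3.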